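Lengthening an Ether Chain: Propyl to Butyl

The source may hold more compounds than are shown below. What is called first, only, known or untested is meant among the compounds shown, and "the series" means these compounds.

Measured compounds:
compound 1 `CCCOc1ccc(O)c(C(=O)/C=C/c2ccc(C)s2)c1`: 23200 nM
compound 2 `CCCCOc1ccc(O)c(C(=O)/C=C/c2ccc(C)s2)c1`: 91700 nM
compound 3 `CCCOc1ccc(OC)cc1C(=O)/C=C/c1ccc(C)s1`: 7000 nM

In a functional assay on Hep 3B2 cells (Homo sapiens) for cytotoxicity, read by MTT assay (a lower number here means a stronger inhibitor, a higher number a weaker inhibitor), compound 1 gives 23200 nM and compound 2 gives 91700 nM. The step of a 4.0-fold higher number from compound 1 to compound 2 (0.60 log units; beyond the scatter) arises from the change (methyl in place of hydrogen on a saturated chain carbon, three bonds along the chain from an oxygen on an aromatic ring). Compound 3 gives 7000 nM, the lowest of the three numbers; the difference between its core and the core of compound 1 is not broken down here.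

Compound 4 `CCCCOc1ccc(OC)cc1C(=O)/C=C/c1ccc(C)s1` differs from compound 3 by methyl in place of hydrogen on a saturated chain carbon, three bonds along the chain from an oxygen on an aromatic ring, the same change as from compound 1 to compound 2, the two place descriptions agreeing word for word; the change occurs twice among these compounds. Going by the values given here, only one earlier step of this change is known, so the expectation for compound 4 rests on it alone. The step of a 3.1-fold higher number from compound 3 to compound 4 (0.50 log units; beyond the scatter) is expected in this assay because a 4.0-fold higher number from compound 1 to compound 2 (0.60 log units; beyond the scatter) points the same way. Compound 4 is estimated at 22000 nM, likely between 8000 nM and 60000 nM.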

Compound 4, half-maximal inhibitory concentration: 10700 nM
The estimate for compound 4 lay 2.1-fold (0.31 log units) above the measured number; the range from low to high includes it.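

In this assay, going from propyl to butyl on the core of compound 3 gives a 1.5-fold higher number from compound 3 to compound 4 (0.18 log units; within the scatter), so on this core the step cannot be told from the scatter of repeated measurements. Two pairs do not fix the size of this step on any further core, and they do not explain why only the earlier step lies beyond the scatter. They do show that, across these two cores, the steps themselves cannot be told apart: the same change on two cores in this assay, a 4.0-fold higher number (0.60 log units; beyond the scatter) from compound 1 to compound 2 and a 1.5-fold higher number (0.18 log units; within the scatter) from compound 3 to compound 4, 2.6-fold (0.41 log units) apart, within the scatter of two such steps

Left open is how a longer chain such as pentyl, or an ether chain carrying an amine, would read in this assay. Also open, as far as these compounds go, is whether the step would hold on any other core.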